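Swapping a difluorophenyl for a hydroxyphenyl on a shared core

The source may report more compounds than this note shows. Statements on the series, on what has been measured and on what is new or still open speak of the compounds shown alone.

Of the compounds shown here, three built on the same core have been tested in a functional assay on A549 cells (Homo sapiens) for antiproliferative activity, read by MTT assay, with a stated time of 72 h; on this read-out higher numbers stand for weaker inhibition and lower numbers for stronger inhibition. Compound 1 `COc1cc(-n2cnc3ccc(-c4cc(F)ccc4F)cc32)cc(OC)c1OC` gives 7940 nM. Compound 2 `COc1cc(-n2cnc3ccc(-c4cccc(C)c4C)cc32)cc(OC)c1OC` gives 9250 nM, and compound 3 `COc1cc(-n2cnc3ccc(-c4ccccc4)cc32)cc(OC)c1OC` gives 3060 nM. Among these three numbers compound 1 stands second highest: it sits close to compound 2, since a 1.2-fold higher number from compound 1 to compound 2 (0.07 log units; within the scatter), while compound 3 lies further away, as a 2.6-fold lower number from compound 1 to compound 3 (0.41 log units; beyond the scatter).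

Compound 4 `COc1cc(-n2cnc3ccc(-c4ccc(O)cc4)cc32)cc(OC)c1OC` has not yet been measured. It differs from compound 1 in one place: 4-hydroxyphenyl in place of 2,5-difluorophenyl on an aromatic carbon.

The steps that speak to this change are those from the two substituted phenyl groups to the bare phenyl. Removing the two fluorines gave a 2.6-fold lower number from compound 1 to compound 3 (0.41 log units; beyond the scatter), and removing the two methyl groups gave a 3.0-fold lower number from compound 2 to compound 3 (0.48 log units; beyond the scatter). Both are modest moves toward a lower number, which suggests that a plain phenyl does somewhat better here than a phenyl carrying two small groups. Compound 4 carries a single hydroxyl instead, a group not seen in any measured compound, so the direction is uncertain. On balance, a modestly lower number is expected from compound 1 to compound 4, a 2.0-fold lower number from compound 1 to compound 4 (0.30 log units; within the scatter), in this assay. Compound 4 is therefore estimated at 4000 nM, with a plausible range from 1000 nM to 16000 nM.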

Compound 4, half-maximal inhibitory concentration: 5090 nM
The estimate for compound 4 lay 1.3-fold (0.10 log units) below the measured number; low and high end bracket the measured number.
By their numbers in this assay, from the lowest: compounds 3, 4, 1 and 2 (each within the scatter of the next, the first and the last beyond it).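

For the compounds shown here, the step from bare phenyl to 4-hydroxyphenyl is the first change of just one group on this ring in this assay, and it stays within the scatter (a 1.7-fold higher number from compound 3 to compound 4 (0.22 log units; within the scatter)), so adding this hydroxyl, with its hydrogen-bond donor, cannot be told apart from leaving the ring bare. Going by these compounds alone, compound 4 also cannot be separated from the two compounds with two groups on the ring (a 1.6-fold lower number from compound 1 to compound 4 (0.19 log units; within the scatter); a 1.8-fold lower number from compound 2 to compound 4 (0.26 log units; within the scatter)), whereas compound 3 stood beyond the scatter from both of them, so the 4-hydroxyphenyl group is the first seen here that lies within the scatter of every other group at this position. The data hold no measurement that could explain these numbers.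

On these data alone, whether a hydroxyl elsewhere on the phenyl ring, or a single fluorine or single methyl, would behave like this hydroxyl remains open, since compounds 1 and 2 each carry two groups. So does the outcome for other groups on this ring, such as an amine, a carboxylic acid or a methoxy group.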